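The compounds below may be only part of what the source reports. "The series", "measured", "known", "first", "only" and "open" are said of these compounds alone.

Compound 1 `Oc1ccc(NC(=S)Nc2ccc3ncnc(Nc4cccc(Br)c4)c3c2)cc1` gives 17300 nM in a functional assay on MDA-MB-231 cells (Homo sapiens) for inhibition, read by MTT assay, with a stated time of 48 h; a higher number here means a weaker inhibitor of growth, a lower number a stronger inhibitor of growth. Compound 2 `NS(=O)(=O)c1ccc(NC(=S)Nc2ccc3ncnc(Nc4cccc(Br)c4)c3c2)cc1` carries sulfamoyl in place of the hydroxy of compound 1. In this assay compound 2 gives > 30000 nM. That value is a limit and not a number, so compound 2 stands only at the limit of > 30000 nM in this assay, at which 1 of the 2 values shown sits.

Compound 3 `O=S(=O)(Nc1nccs1)c1ccc(NC(=S)Nc2ccc3ncnc(Nc4cccc(Br)c4)c3c2)cc1` keeps the sulfonamide of compound 2 but substitutes it, with 1,3-thiazol-2-yl in place of hydrogen on a sulfonamide nitrogen.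

For the measured compounds named here, only one measured step bears on this change, and only indirectly: an at least 1.7-fold higher number from compound 1 to compound 2 (0.23 log units; that floor lies within the scatter). Going by the values given here, it replaces the whole group on the aromatic carbon, and no measured step alters a sulfonamide nitrogen. It therefore gives no firm guide to direction, and the starting point is itself a limit. No shift beyond the scatter is expected in this assay, and the expected step is an at least 1.2-fold lower number from compound 2 to compound 3 (0.07 log units; that floor lies within the scatter). A reading at the limit is as likely as a number.

For compound 3 the estimate is 25000 nM, with an expected range from 9000 nM to 70000 nM.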

Compound 3, concentration for 50% growth inhibition: > 30000 nM
Compound 3: a limit, no number (the forecaster's own chance of this, stated with the estimate: 50%); middle value at least 1.2-fold (0.07 log units) from the limit.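

In this assay compound 3 gives > 30000 nM and that value is a limit and not a number. Compound 2 and compound 3 both stand at a limit, so the step between them cannot be read, and nothing shows whether 1,3-thiazol-2-yl in place of hydrogen on the sulfonamide nitrogen changes growth inhibition. Set against the hydroxy group on the aromatic carbon, the change reads as an at least 1.7-fold higher number from compound 1 to compound 3 (0.23 log units; that floor lies within the scatter) and so gives no separation beyond the scatter, while the substituted sulfonamide joins the unsubstituted one at the same limit: the limit of > 30000 nM in this assay, at which 2 of the 3 values shown sit.

The compounds shown leave open whether any group on the sulfonamide nitrogen, such as methyl or pyridin-2-yl, would bring a number back within range in this assay at all. They also leave open whether an amine or a carboxylic acid on the aromatic carbon would fall nearer to compound 1 or would likewise reach the limit.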